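The source may report more compounds than this note shows. Statements on the series, on what has been measured and on what is new or still open speak of the compounds shown alone.

Working notes on the series. Two compounds have numbers in a functional assay on NIH3T3 cells (Mus musculus) for inhibition, read by MTT assay, with a stated time of 72 h (a lower number here means a stronger inhibitor, a higher number a weaker inhibitor), so far. Compound 1 `C=C1CC[C@@H]2[C@](C)(CO)[C@H](O)CC[C@@]2(C)[C@@H]1CCC1=CCOC1=O` gives 176000 nM in this assay, and compound 2 `C=C1CC[C@H]2[C@@](C)(CC[C@@H](OC(C)=O)[C@@]2(C)C(=O)OCc2ccccn2)[C@@H]1CCC1=CCOC1=O` gives 55500 nM. Compound 1 thus stands highest of the two numbers; the nearest, compound 2, sits lower by a margin that is beyond the usual scatter. Compound 3 `C=C1CC[C@H]2[C@@](C)(CC[C@@H](O)[C@@]2(C)C(=O)OC)[C@@H]1CCC1=CCOC1=O` has not yet been measured in this assay. It differs from compound 1 by methoxycarbonyl in place of hydroxymethyl on a saturated ring carbon. Among the measured compounds shown here, no step between measured compounds is available for this change; compound 2 differs from compound 1 in more than one place, so it offers only a rough pointer. The expected step is a 2.2-fold lower number from compound 1 to compound 3 (0.34 log units; beyond the scatter), toward a lower number, and it is not expected to exceed a modest size. For compound 3 the estimate in this assay is 80000 nM, with a range from 30000 nM to 200000 nM.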

Compound 3, half-maximal inhibitory concentration: 60600 nM
Compound 3: middle estimate off by 1.3-fold (0.12 log units), on the high side; measured number inside the range.
By their numbers in this assay, from the lowest: compounds 2 and 3 (each within the scatter of the next); then compound 1.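

In this assay, among the compounds shown here, methoxycarbonyl in place of hydroxymethyl on this saturated ring carbon gives a 2.9-fold lower number from compound 1 to compound 3 (0.46 log units; beyond the scatter), the first step that can be read at a single place. The number therefore responds to what this carbon carries, with the hydroxy group on the neighbouring ring atom and the rest of the core unchanged. The step is modest, and no measurement on hand accounts for it.

With one exchange at this carbon, the step cannot be assigned to the carbonyl, the added methyl or the loss of the hydroxymethyl group. Going by these compounds, a carboxylic acid, a primary amide or a longer ester such as ethoxycarbonyl at this position would help separate these readings, and how the number responds to any of them remains open.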